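Trifluoromethyl for Methyl, Carried onto a Second Core

This account rests on a few compounds, and the source may have more. Where it says the series, first, only, none or still open, it means among the compounds named here.

All values below come from a functional assay on SMMC-7721 cells (Homo sapiens) for cytotoxicity, read by MTT assay, with a stated time of 4 days; a higher number here means a weaker inhibitor, a lower number a stronger inhibitor.

Compound 1 `C=C1C(=O)[C@]23C[C@@]1(O)CC[C@H]2c1ccc(O)c(C)c1[C@@H]3Cn1cc(-c2ccc(C(F)(F)F)cc2)nn1` gives 1440 nM.
Compound 2 `C=C1C(=O)[C@]23C[C@@]1(O)CC[C@H]2c1ccc(O)c(C)c1[C@@H]3Cn1cc(-c2ccc(C)cc2)nn1` gives 920 nM.
Compound 3 `Cc1ccc(-c2cn(C[C@H]3c4c(ccc(OS(=O)(=O)c5ccc(C)cc5)c4C)[C@@H]4CC[C@@]5(C)C[C@]43CC5=O)nn2)cc1` reaches only the limit of this assay, > 20000 nM.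

Compound 1 and compound 2 share one core and differ in a single place: trifluoromethyl in place of methyl on an aromatic carbon. The measured step is a 1.6-fold higher number from compound 2 to compound 1 (0.19 log units; within the scatter), so the two values cannot be told apart with confidence.

Compound 3 carries a different core, and the difference between the two cores is not broken down here. Compound 4 `Cc1ccc(S(=O)(=O)Oc2ccc3c(c2C)[C@H](Cn2cc(-c4ccc(C(F)(F)F)cc4)nn2)[C@@]24CC(=O)[C@@](C)(CC[C@@H]32)C4)cc1` has not yet been measured. Going by the values given here, it differs from compound 3 by trifluoromethyl in place of methyl on an aromatic carbon, and since the surroundings of the place are described in the same words for both pairs, this is the same change as the one from compound 2 to compound 1, now made on the core of compound 3. Compound 3 sits at the limit of > 20000 nM in this assay, at which 1 of the 3 values shown sits, so no number, only a limit, is known for the starting point.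

The step from compound 3 to compound 4 is expected to be small, about a step that the limit leaves unreadable from compound 3 to compound 4, resting on the small measured step from compound 2 to compound 1. Because compound 3 already gives only the limit > 20000 nM, compound 4 is expected to report a limit again rather than a number. The estimate for compound 4 is 30000 nM, with a range from 12000 nM to 80000 nM.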

Compound 4, half-maximal inhibitory concentration: > 20000 nM
Compound 4: a limit, no number; the forecaster's own chance of this, stated with the estimate: 85%; the middle value does not contradict the limit.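

In this assay compound 4 gives > 20000 nM, a limit and not a number. No step can be read from compound 3 to compound 4, because both stand at a limit: the limit of > 20000 nM in this assay, at which 2 of the 4 values shown sit.

The compounds shown leave open whether trifluoromethyl in place of methyl makes any difference on the core of compound 3, as neither compound there has a true number.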